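A few compounds are considered here, and "the series" means these few. Any claim that something is new, unique, unknown or untested is made for them only; others in the source may bear on it.

Working notes. Going by the values given here, in an assay on microsomes from intestine for inhibition of acyl-CoA:cholesterol acyltransferase (Oryctolagus cuniculus) (a higher number here means a weaker inhibitor, a lower number a stronger inhibitor), compound 2 `CCCCCCCCCCCCS(=O)(=O)NC(=O)Nc1c(C(C)C)cccc1C(C)C` gives 2330 nM, the lowest of the two numbers so far; compound 1 `CCCCCCCCCCS(=O)(=O)NC(=O)Nc1c(C(C)C)cccc1C(C)C` gives 11100 nM in this assay, and the step of a 4.8-fold lower number from compound 1 to compound 2 (0.68 log units; beyond the scatter) is modest. Compound 3 `CCCCCCCCCCCCS(=O)(=O)N(C)C(=O)Nc1c(C(C)C)cccc1C(C)C` differs from compound 2 by methyl in place of hydrogen on an amide-type nitrogen, so the change sits on the amide-type nitrogen rather than on the chain. Among the compounds with values here, no measured step touches that nitrogen, so the earlier step gives no direct guide; the expectation for compound 3 is an uncertain step of a 2.1-fold higher number from compound 2 to compound 3 (0.33 log units; beyond the scatter). Compound 3 is estimated at 5000 nM, with a range of 1500 nM to 20000 nM.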

Compound 3, half-maximal inhibitory concentration: 86 nM
Compound 3: the middle estimate sits 58-fold (1.76 log units) above what was measured; measured number outside the range, below it.
By their numbers in this assay, from the lowest: compound 3; then compound 2; then compound 1.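

In this assay, methyl in place of hydrogen on the amide-type nitrogen gives a 27-fold lower number from compound 2 to compound 3 (1.43 log units; beyond the scatter), so the hydrogen on this nitrogen is not needed for inhibition in compound 3. The earlier compounds shown here varied only the chain, and this result shows that a change of one heavy atom at the nitrogen can also move the number substantially. No measurement here accounts for this step.

From the compounds shown here alone, whether ethyl or a benzyl group on this nitrogen would keep the lower number remains open. Also open, going by these compounds, is whether the chain effect seen in a 4.8-fold lower number from compound 1 to compound 2 (0.68 log units; beyond the scatter) persists with methyl on the nitrogen.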